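This account rests on a few compounds, and the source may have more. Where it says the series, first, only, none or still open, it means among the compounds named here.

Compound 1 `N#Cc1cc2c(Oc3ccc(F)cc3OCCn3ccc(=O)[nH]c3=O)cccn2c1` was examined in an ADME assay on MT2 cells (Homo sapiens) for cytotoxicity, read by MTT assay (on this read-out higher numbers stand for lower toxicity in this test and lower numbers for higher toxicity in this test), where compound 1 gives 100000 nM. Compound 2 `N#Cc1cc2c(Oc3ccccc3OCCn3ccc(=O)[nH]c3=O)cccn2c1` differs from it in one place, namely (hydrogen in place of fluoro on an aromatic carbon). In this assay compound 2 reaches only a limit of the test, > 100000 nM. That change gave a number no lower from compound 1 to compound 2 (the limit leaves the size open). Compound 3 `N#Cc1ccc2c(Oc3ccc(F)cc3OCCn3ccc(=O)[nH]c3=O)cccc2c1` is built on a different core; how the two cores differ is not broken down here. In this assay compound 3 also sits at a limit, > 100000 nM. Compound 4 `N#Cc1ccc2c(Oc3ccccc3OCCn3ccc(=O)[nH]c3=O)cccc2c1` has not yet been measured and stands to compound 3 as compound 2 stands to compound 1: hydrogen in place of fluoro on an aromatic carbon, the same change at the same place on the ring. Because (the limit of > 100000 nM in this assay, at which 2 of the 3 values shown sit), there is little room in these numbers for a step to show itself in either direction. For compound 4 the expected step is a number no higher from compound 3 to compound 4 (the limit leaves the size open), mirroring the earlier one. Compound 4 is therefore estimated at 100000 nM in this assay, with a fair chance that only a limit is reported once more.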

Compound 4, half-maximal cytotoxic concentration: > 100000 nM
Compound 4 was reported as a limit; the forecaster's own chance of this, stated with the estimate: 70%; the middle value lies on the limit itself.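

Within the data shown here, compound 3 and compound 4 both give only a limit, so replacing fluoro with hydrogen between them yields no step that can be read, because the values offer no room to show one: the limit of > 100000 nM in this assay, at which 3 of the 4 values shown sit. The compounds shown leave open how large any effect of this change is in this assay on either core.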